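This account rests on a few compounds, and the source may have more. Where it says the series, first, only, none or still open, it means among the compounds named here.

Measured so far in an assay on Sf9 cells for inhibition of mitogen-activated protein kinase kinase kinase 20 (Homo sapiens), read by ADP-Glo, with a stated time of 30 min; on this read-out higher numbers stand for weaker inhibition and lower numbers for stronger inhibition:
compound 1, `COc1n[nH]c2ncc(-c3cn(-c4c(F)ccc(NS(=O)(=O)c5cccc(Cl)c5)c4F)nn3)cc12`: 1.9 nM
compound 2, `Nc1ncc(-c2cn(-c3c(F)ccc(NS(=O)(=O)c4cccc(Cl)c4)c3F)nn2)cn1`: 8.9 nM

Compound 1 gives the lowest number of the two; the nearest is compound 2, and the step of a 4.7-fold higher number from compound 1 to compound 2 (0.67 log units; beyond the scatter) is beyond the scatter. That step exchanges the group on the triazole, not the sulfonamide part, so it says nothing direct about what follows.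

The unmeasured compound is compound 3, `COc1n[nH]c2ncc(-c3cn(-c4c(F)ccc(NS(=O)(=O)c5ccccc5)c4F)nn3)cc12`. It differs from compound 1 in one place: hydrogen in place of chloro on an aromatic carbon of a six-membered aromatic ring of carbon only, meta to a large group. No measured pair changes the chlorophenyl sulfonyl group, so the size of this step in this assay is not anchored by any shown step. With nothing against it, compound 3 is expected to show a step of a 2.4-fold higher number from compound 1 to compound 3 (0.37 log units; beyond the scatter), i.e. a somewhat higher number than compound 1, likely at the edge of the scatter. Compound 3 is therefore expected at 4.5 nM, with a range of 1.5 nM to 14 nM.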

Compound 3, half-maximal inhibitory concentration: 3.8 nM
For compound 3 the middle estimate is 1.2-fold (0.07 log units) above the measured one; measured number inside the range.
By their numbers in this assay, from the lowest: compounds 1 and 3 (each within the scatter of the next); then compound 2.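

In this assay, hydrogen in place of chloro on the aromatic carbon of the 3-chlorophenyl group gives a 2.0-fold higher number from compound 1 to compound 3 (0.30 log units; within the scatter), so this exchange cannot be told apart from repeat-measurement noise. Within the data shown here, this is the first reading on the sulfonamide side of the series, since the earlier step changed only the group on the triazole, and it shows that compound 3, at 3.8 nM, keeps a low nanomolar number without the chloro. No independent data bear on why this exchange has so small an effect on the read-out.

Still open, on these data alone, is whether a larger or differently charged group at the same place, such as an amine, a carboxylic acid or a longer alkyl chain, would stay within the scatter of compound 1 or would move the number beyond it. Also open, as far as these compounds go, is whether the exchange of chloro for hydrogen reads the same with the aminopyrimidine-type group of compound 2 on the triazole, since this single pair rests on the core of compound 1 alone.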